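A Methyl Added Beside Nothing Readable

The source may report more compounds than this note shows. Statements on the series, on what has been measured and on what is new or still open speak of the compounds shown alone.

Of the compounds shown here, three have so far been measured in a functional assay on MCF7 cells (Homo sapiens) for antiproliferative activity, read by cell counting, with a stated time of 5 days; on this read-out lower numbers stand for stronger inhibition and higher numbers for weaker inhibition. Compound 1 `COc1ccc(-c2cc(-c3ccc(OC)cc3)on2)cc1` carries two methoxy groups on its core; in this assay compound 1 reaches only the limit > 100000 nM, which is a limit and not a number. Compound 2 `COc1ccc(-c2noc(-c3ccc(OC)cc3)c2C)cc1` adds a methyl to that core and likewise stops at the limit > 100000 nM in this assay. The step that the two limits leave unreadable from compound 1 to compound 2 therefore cannot be read because the limit of > 100000 nM in this assay, at which 2 of the 3 values shown sit, holds both of its ends.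

Among the measured compounds shown here, compound 3 `Oc1ccc(-c2cc(-c3ccc(O)cc3)on2)cc1` is the only one to give a number: in this assay compound 3 gives 5200 nM. Since compound 1 and compound 2 reach only the limit, compound 3 stands alone on the numbers and no ordering against it can be drawn.

Compound 4 `Cc1c(-c2ccc(O)cc2)noc1-c1ccc(O)cc1` differs from compound 3 by methyl in place of hydrogen on an aromatic carbon. For the measured compounds named here, the single measured step of the same kind, a step that the two limits leave unreadable from compound 1 to compound 2, offers no size, so nothing measured tells how such a methyl moves this assay. In the absence of a readable precedent, the step of a 1.0-fold lower number from compound 3 to compound 4 (0.02 log units; within the scatter) is expected to stay within the usual scatter, in no set direction. Compound 4 is thus estimated at 5000 nM in this assay, with a range from 1500 nM to 20000 nM.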

Compound 4, half-maximal inhibitory concentration: 48000 nM
For compound 4 the middle estimate is 9.6-fold (0.98 log units) below the measured one, outside the stated range (above it).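

In this assay the change of methyl in place of hydrogen on an aromatic carbon of the five-membered aromatic ring now has a size: the pair shows a 9.2-fold higher number from compound 3 to compound 4 (0.97 log units; beyond the scatter) and so weaker inhibition with the methyl. This carbon, two ring bonds from the ring nitrogen and two ring bonds from the ring oxygen, is therefore not indifferent to a methyl when the core carries hydroxy groups, and compound 4 still gives a number and not a limit. The earlier pair with methoxy groups could show none of this, because both of its compounds stop at a limit of the assay: the limit of > 100000 nM in this assay, at which 2 of the 4 values shown sit.

Whether the methyl has a similar effect on the core with methoxy groups stays unreadable, and a single readable pair neither explains the step nor sets a pattern. As far as these compounds go, how an ethyl group, a chlorine atom or an amine on the same carbon would compare with the hydrogen of compound 3 in this assay remains open, as does what a longer chain there would do.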